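Cytotoxicity notes: isobutyl to cyclohexyl

This account rests on a few compounds, and the source may have more. Where it says the series, first, only, none or still open, it means among the compounds named here.

Measured in an ADME assay on RAW264.7 cells (Mus musculus) for cytotoxicity, read by MTT assay; on this read-out lower numbers stand for stronger inhibition and higher numbers for weaker inhibition:
Compound 1 `CC(C)CCOc1cccc(O)c1C(=O)/C=C/c1ccc(O)cc1` gives > 30000 nM
Compound 2 `CCCCCCCCC(CCCCCC)CCOc1cccc(O)c1C(=O)/C=C/c1ccc(O)cc1` gives > 30000 nM

Compound 1 stands at a limit of the assay, > 30000 nM, and not at a number. Going by the values given here, the series so far shows (the limit of > 30000 nM in this assay, at which 2 of the 2 values shown sit). Compound 3 `O=C(/C=C/c1ccc(O)cc1)c1c(O)cccc1OCC1CCCCC1` has cyclohexyl in place of isobutyl on a saturated chain carbon bound to an oxygen on an aromatic ring. Among the compounds with values here, no measured step is available, so no step size can be read from the series. In this assay, no step beyond the scatter is expected, in either direction. This expectation rests on compound 1, which gives > 30000 nM, a limit. The expected change is a number no higher from compound 1 to compound 3 (the limit leaves the size open). The estimated value for compound 3 is 30000 nM, with an expected range of 15000 nM to 60000 nM.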

Compound 3, half-maximal inhibitory concentration: > 30000 nM
Compound 3 gave a limit, no number; the forecaster's own chance of this, stated with the estimate: 85%; the middle value sits exactly at the limit.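

No new step can be read from compound 1 to compound 3 in this assay because both values are limits and not numbers: the limit of > 30000 nM in this assay, at which 3 of the 3 values shown sit.

The compounds shown leave open how the isobutyl and cyclohexyl compounds compare beyond that limit.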